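One ring atom exchanged in the group on the core

The source may report more compounds than this note shows. Statements on the series, on what has been measured and on what is new or still open speak of the compounds shown alone.

In a physicochemical assay for solubility, in phosphate buffer, at pH 7.4 (on this read-out higher numbers stand for higher solubility and lower numbers for lower solubility), compound 1 (`CC(=O)N[C@@H]1CCC[C@H](C(=O)Nc2cc(-c3cnn(C)c3C)c(Cl)cn2)C1`) gives 960000 nM and compound 2 (`CC(=O)N[C@@H]1CCC[C@H](C(=O)Nc2cc(-c3cnc4n3CCC4)c(Cl)cn2)C1`) gives 490000 nM as its reading. Compound 3 (`CC(=O)N[C@@H]1CCC[C@H](C(=O)Nc2cc(-c3cnn4c3NCCC4)c(Cl)cn2)C1`) gives 860000 nM and has no real separation from either of the others, since all three readings lie within the usual scatter of one another. Compound 4 (`CC(=O)N[C@@H]1CCC[C@H](C(=O)Nc2cc(-c3cnn4c3OCCC4)c(Cl)cn2)C1`) has not been measured yet. It differs from compound 3 in the group on an aromatic carbon, ortho to a chloro group (a group of 9 heavy atoms (6 carbon, 2 nitrogen, 1 oxygen; one five-membered aromatic ring with 2 hetero atoms, one six-membered non-aromatic ring with 2 hetero atoms) in place of a group of 9 heavy atoms (6 carbon, 3 nitrogen; one five-membered aromatic ring with 2 hetero atoms, one six-membered non-aromatic ring with 2 hetero atoms), on an aromatic carbon), so oxygen enters where one nitrogen leaves and the hydrogen-bond donor count goes from 1 to 0. Within the data shown here, no measured step makes this exact exchange. The nearest evidence is the three swaps of other groups at this same place, namely a 2.0-fold lower number from compound 1 to compound 2 (0.29 log units; within the scatter) and a 1.1-fold lower number from compound 1 to compound 3 (0.05 log units; within the scatter) and a 1.8-fold higher number from compound 2 to compound 3 (0.24 log units; within the scatter) and none of these passes the scatter. On that evidence, starting from compound 3 at 860000 nM as the reference, no step beyond the scatter is expected in either direction. The expected step is a 1.1-fold lower number from compound 3 to compound 4 (0.03 log units; within the scatter) and it remains an estimate. The estimate for compound 4 is 800000 nM with a range from 400000 nM to 1500000 nM as the expected bounds.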

Compound 4, solubility: 110000 nM
Beside the measured number, compound 4's estimate is 7.3-fold (0.86 log units) above it; measured number outside the range, below it.
By their numbers in this assay, from the lowest: compound 4; then compounds 2, 3 and 1 (each within the scatter of the next).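

Among compounds 1, 2 and 3, the group at this place, on an aromatic carbon ortho to a chloro group, could change with no reading in this assay separating from the others, yet exchanging a single nitrogen for oxygen gives a 7.8-fold lower number from compound 3 to compound 4 (0.89 log units; beyond the scatter) and shows that this place can respond after all. Among these compounds, compound 4 also stands clear of the two remaining compounds, with a 4.5-fold lower number from compound 2 to compound 4 (0.65 log units; beyond the scatter) and an 8.7-fold lower number from compound 1 to compound 4 (0.94 log units; beyond the scatter), so the size of the group alone does not set it apart: the group in compound 4 has the same heavy-atom count as the one in compound 3, and of these four groups only this one holds oxygen. Nothing measured here accounts for the lower reading of compound 4.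

With a single oxygen-bearing group, the effect of the oxygen atom cannot be separated from that of the particular ring that holds it. As far as these compounds go, whether a sulfur atom or a methylated amine nitrogen in that ring would read like compound 3 or like compound 4 remains open.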